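An Acetyl-to-Hydrogen Swap Carried Over to a Second Core

The source may hold more compounds than are shown below. What is called first, only, known or untested is meant among the compounds shown, and "the series" means these compounds.

Measured so far in an ADME assay on HT-29 cells (Homo sapiens) for cytotoxicity, read by MTT assay, with a stated time of 72 h; a higher number here means a weaker inhibitor, a lower number a stronger inhibitor:
compound 1, `COc1ccc(C2=C(c3cc(OC)c(OC)c(OC)c3)C(=O)C(OC(C)=O)C2)cc1`, gives < 1 ug/mL, a limit of the assay.
compound 2, `COc1ccc(C2=C(c3cc(OC)c(OC)c(OC)c3)C(=O)C(O)C2)cc1`, gives < 1 ug/mL, also a limit.
compound 3, `CC(=O)OC1C/C(=N/O)C(c2ccccc2)=C1c1ccccc1`, gives > 100 ug/mL, again a limit.

From compound 1 to compound 2 the change is hydrogen in place of acetyl on an oxygen on a saturated carbon. The step that the two limits leave unreadable from compound 1 to compound 2 cannot be read because the limit of < 1 ug/mL in this assay, at which 2 of the 3 values shown sit, holds both values. The difference between the core of compound 1 and the core of compound 3 is not broken down here. Compound 4, `O/N=C1/CC(O)C(c2ccccc2)=C1c1ccccc1`, carries the same change on the core of compound 3: hydrogen in place of acetyl on an oxygen on a saturated carbon. Among the measured compounds shown here, compound 3 sits at the limit of > 100 ug/mL in this assay, at which 1 of the 3 values shown sits, and the one earlier example of this change gives no readable size, so nothing here points to a shift. Compound 4 is therefore expected to remain weak in this assay, with an estimate of 100 ug/mL, spanning 30 ug/mL to 300 ug/mL. The step is expected to be a number no higher from compound 3 to compound 4 (the limit leaves the size open), resting on compound 3 at the limit of > 100 ug/mL in this assay, at which 1 of the 3 values shown sits, and on the unreadable a step that the two limits leave unreadable from compound 1 to compound 2.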

Compound 4, half-maximal inhibitory concentration: > 100 ug/mL
Compound 4 gave a limit, no number (the forecaster's own chance of this, stated with the estimate: 70%); the middle value lies on the limit itself.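

Compound 3 and compound 4 both sit at a limit of this assay, not at a number, and the step between them cannot be read. The compounds shown leave open how large the change from acetoxy to hydroxy is on either core.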